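From Trifluoromethyl to Cyano, Without a Starting Number

The compounds below may be only part of what the source reports. "The series", "measured", "known", "first", "only" and "open" are said of these compounds alone.

Only a few measurements exist in this small set of amides. In an ADME assay for permeability, using PAMPA (a higher number here means that the compound crosses the layer faster, a lower number that the compound crosses the layer more slowly), compound 1 `O=C(Nc1ccccc1C(F)(F)F)c1cc(Cl)ccc1O` gives 26 10^-6 cm/s. Compound 2 `O=C(Nc1c(Cl)cccc1Cl)c1cc(Cl)ccc1O` gives 73 10^-6 cm/s in this assay. Compound 3 `O=C(Nc1ccc(C(F)(F)F)cc1Cl)c1ccc2ccccc2c1O` is the natural starting point for the next step, but its entry in this assay reads "not determined" (no result reported). Compound 3 therefore has no position on the scale, and there is no number from which to measure a rise or a fall.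

The next compound, compound 4 `N#Cc1ccc(NC(=O)c2ccc3ccccc3c2O)c(Cl)c1`, is still unmeasured. The structural change is cyano in place of trifluoromethyl on an aromatic carbon, meta to a chloro group and para to a large group. Among the measured compounds shown here, no measured pair here shows this exchange, so the data cannot give its size. The expected step in this assay is a small downward one, not clearly beyond the usual scatter, and this is a judgement with little support from the data. For the measured compounds named here, the only numerical guide is the pair of values already seen, compound 1 at 26 10^-6 cm/s and compound 2 at 73 10^-6 cm/s, and both belong to a different core. Compound 4 is expected at about 25 10^-6 cm/s, with an estimated range from 8 10^-6 cm/s to 70 10^-6 cm/s.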

Compound 4, apparent permeability in the ADME assay: 111 10^-6 cm/s
Estimate against measurement, compound 4: 4.4-fold (0.65 log units) below; the measured number lies above the stated range.
By their numbers in the ADME assay, from the lowest: compound 1; then compounds 2 and 4 (each within the scatter of the next).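

Among the compounds shown here, in the ADME assay compound 3 stands as "not determined" (no result reported) and has no single number, so no step from compound 3 to compound 4 can be read in this assay. The compounds shown leave open how far cyano in place of trifluoromethyl on an aromatic carbon moves this read-out, on this core or on any other.

In a physicochemical assay for solubility (a higher number here means a more soluble compound, a lower number a less soluble compound), compound 3 gives < 1 ug/mL as a limit of the assay and not a number. In the physicochemical assay compound 4 gives 6 ug/mL as a measured number. In the physicochemical assay the exchange shows an at least 6.0-fold higher number from compound 3 to compound 4 (0.77 log units; beyond the scatter) as the step that can be read.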